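Working notes: substituent change at the triple-bonded carbon

This account rests on a few compounds, and the source may have more. Where it says the series, first, only, none or still open, it means among the compounds named here.

Measured compounds:
compound 1, `O=c1[nH]c(=O)n([C@H]2C[C@H](O)[C@@H](CO)O2)cc1C#Cc1ccccc1`, a functional assay on L1210 cells (Mus musculus); a lower number here means a stronger inhibitor, a higher number a weaker inhibitor: 494 ug/mL
compound 2, `COCC#Cc1cn([C@H]2C[C@H](O)[C@@H](CO)O2)c(=O)[nH]c1=O`, this assay: 254 ug/mL

Compound 2 holds the lower of the two numbers, but the step of a 1.9-fold lower number from compound 1 to compound 2 (0.29 log units; within the scatter) lies within the scatter, so the two compounds cannot be ordered. Compound 3, `CC(C)(C)C#Cc1cn([C@H]2C[C@H](O)[C@@H](CO)O2)c(=O)[nH]c1=O`, differs from compound 2 by tert-butyl in place of methoxymethyl on a triple-bonded carbon. Within the data shown here, the only measured step at this position is a 1.9-fold lower number from compound 1 to compound 2 (0.29 log units; within the scatter), and it stayed within the scatter. Compound 3 is therefore expected to show no step beyond the scatter, a 1.2-fold higher number from compound 2 to compound 3 (0.07 log units; within the scatter). The estimate for compound 3 in this assay is 300 ug/mL, with a range from 120 ug/mL to 750 ug/mL.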

Compound 3, concentration for 50% inhibition: 287 ug/mL
The estimate for compound 3 lay 1.0-fold (0.02 log units) above the measured number, within the range that was stated.
By their numbers in this assay, from the lowest: compounds 2, 3 and 1 (each within the scatter of the next).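

In this assay tert-butyl on the triple-bonded carbon cannot be told apart from either methoxymethyl (a 1.1-fold higher number from compound 2 to compound 3 (0.05 log units; within the scatter)) or phenyl (a 1.7-fold lower number from compound 1 to compound 3 (0.24 log units; within the scatter)). Tert-butyl has neither the hydrogen-bond acceptor of methoxymethyl nor the ring of phenyl, yet all three groups remain within the scatter of one another, so neither feature separates these compounds here. Nothing further is available to interpret this result.

On these data alone, whether any group at this position can give a step beyond the scatter stays open. An amine, a carboxylic acid or a longer chain would test this.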